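The compounds below may be only part of what the source reports. "The series", "measured", "known", "first", "only" and "open" are said of these compounds alone.

Compound 3, `Cc1cc(Nc2cc(Cl)ccc2Cl)nc(N)n1`, is one of three close analogues tested in an assay on cells for inhibition of S-adenosylmethionine decarboxylase proenzyme (Homo sapiens), read by mass spectrometry, at pH 7.2; a higher number here means a weaker inhibitor, a lower number a stronger inhibitor. In this assay compound 3 gives a limit, > 180000 nM, and not a number. Compound 1, `Cc1nc(N)cc(Nc2cc(Cl)cc(Br)c2)n1`, likewise ends at a limit, > 180000 nM. Compound 2, `Cc1cc(Nc2cc(Cl)c(N(C)C)c(Cl)c2)nc(N)n1`, also stops at a limit, > 180000 nM. Compound 3 therefore stands nowhere distinct among the three; the picture is simply (the limit of > 180000 nM in this assay, at which 3 of the 3 values shown sit). The next compound, compound 4, `Cc1cc(Nc2cc(Cl)ccc2C)nc(N)n1`, differs from compound 3 by methyl in place of chloro on an aromatic carbon. Within the data shown here, no step between measured compounds exists here, so the expected step is a step that the limit leaves unreadable from compound 3 to compound 4, none beyond the scatter. Compound 4 is accordingly estimated at about 200000 nM, within 50000 nM to 800000 nM, most probably again reported as a limit.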

Compound 4, half-maximal inhibitory concentration: > 180000 nM
Compound 4 ended at the assay's limit (the forecaster's own chance of this, stated with the estimate: 80%); the middle value is on the limit's open side.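

No step can be read from compound 3 to compound 4, because both end at a limit: (the limit of > 180000 nM in this assay, at which 4 of the 4 values shown sit). The compounds shown leave open whether any change to the shared core gives a measurable value in this assay at all.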